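A Chlorine-for-Fluorine Swap on the Benzyl Group

The compounds below may be only part of what the source reports. "The series", "measured", "known", "first", "only" and "open" are said of these compounds alone.

Compound 1 `Cc1ccc(/C=C2\CN(C(=S)SCc3cn(Cc4ccc(F)cc4)nn3)C/C(=C\c3ccc(C)cc3)C2=O)cc1`: 81600 nM
Compound 2 `O=C1/C(=C/c2ccccc2F)CN(C(=S)SCc2cn(Cc3ccccc3F)nn2)C/C1=C\c1ccccc1F`: 51600 nM
Compound 3 `COc1ccc(/C=C2\CN(Cc3cn(Cc4ccccc4Cl)nn3)C/C(=C\c3ccc(OC)cc3)C2=O)cc1`: > 100000 nM (a limit)

These three compounds were tested in a functional assay on MCF7 cells (Homo sapiens) for cytotoxicity, read by MTT assay, with a stated time of 24 h; on this read-out higher numbers stand for weaker inhibition and lower numbers for stronger inhibition. Only two of them returned a number, compound 1 at 81600 nM and compound 2 at 51600 nM, and these two values lie within the usual scatter of each other. Compound 1 therefore stands level with compound 2 on these data. For compound 3 the result is only a limit, > 100000 nM.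

The next compound, compound 4 `Cc1ccc(/C=C2\CN(C(=S)SCc3cn(Cc4ccccc4Cl)nn3)C/C(=C\c3ccc(C)cc3)C2=O)cc1`, keeps the core of compound 1 and changes one group: 2-chlorophenyl in place of 4-fluorophenyl on a saturated chain carbon bound to an aromatic nitrogen, which is the same as 4-fluorobenzyl to 2-chlorobenzyl (2-chlorophenyl in place of 4-fluorophenyl on a saturated chain carbon bound to an aromatic nitrogen). For the measured compounds named here, no two measured compounds differ in one place only, so the size of this change has no direct precedent here. Going by the values given here, the closeness of compound 1 at 81600 nM to compound 2 at 51600 nM gives the only guide, and no shift beyond the scatter is expected in either direction. The estimated change is a 1.3-fold lower number from compound 1 to compound 4 (0.10 log units; within the scatter). For compound 4 the expected half-maximal inhibitory concentration is 65000 nM, with an estimated range from 28000 nM to 130000 nM.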

Compound 4, half-maximal inhibitory concentration: > 100000 nM
Compound 4 ended at the assay's limit; the forecaster's own chance of this, stated with the estimate: 20%; middle value at least 1.5-fold (0.18 log units) from the limit.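

In this assay, for the compounds shown here, the change from 4-fluorobenzyl to 2-chlorobenzyl gives the first comparison in which the compounds differ in one place only, on a saturated chain carbon bound to an aromatic nitrogen, and it reads as an at least 1.2-fold higher number from compound 1 to compound 4 (0.08 log units; that floor lies within the scatter). Compound 4 gives > 100000 nM, which is a limit of the assay and not a number. The step therefore has a floor but no upper end, and since that floor lies within the scatter, it does not establish a real difference at this position, though a larger one is not excluded, because the read-out stops at the assay's limit: the limit of > 100000 nM in this assay, at which 2 of the 4 values shown sit.

As far as these compounds go, how far compound 4 lies past that limit remains open, and so does whether this change separates from compound 1 at all in a measurement with a wider range. From the compounds shown here alone, how a 4-chlorobenzyl group or a plain benzyl group would read on the same core also stays open, so the exchange of fluorine for chlorine cannot be told apart from the shift of the halogen's place on the ring.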